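The source may hold more compounds than are shown below. What is called first, only, known or untested is meant among the compounds shown, and "the series" means these compounds.

In a physicochemical assay for lipophilicity, using the shake flask method, measured as octanol-water partition, with a stated time of 30 min, at pH 7.4 (on this read-out lower numbers stand for lower lipophilicity and higher numbers for higher lipophilicity), compound 1 (`Cc1ncccc1-c1nc2cn(-c3cccc(OC(C)C)c3)nc2c(=O)n1C[C@H]1CCCN(C[C@H]2CCCO2)C1`) gives 2.7 and compound 2 (`Cc1ncccc1-c1nc2cn(-c3cccc(OC(F)F)c3)nc2c(=O)n1C[C@H]1CCCN(C[C@H]2CCCO2)C1`) gives 2.2, the lower of the two numbers. Compound 3 (`Cc1ncccc1-c1nc2cn(-c3ccccc3)nc2c(=O)n1C[C@H]1CCCN(C[C@H]2CCCO2)C1`) is not yet measured. It has hydrogen in place of difluoromethoxy on an aromatic carbon. Going by the values given here, only one measured step bears on this change: a number 0.50 log units lower from compound 1 to compound 2 (beyond the scatter), modest but beyond the scatter, with a different group on the same oxygen. Among the compounds with values here, no measured step removes the whole group, so a further modest fall in this assay is only an expectation. The estimated change is a number 0.40 log units lower from compound 2 to compound 3 (beyond the scatter). Compound 3 is expected at 1.8, within an estimated range of 1.4 to 2.2.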

Compound 3, distribution coefficient: 1.7
The estimate for compound 3 lay 0.10 log units above the measured number; low and high end bracket the measured number.
By their numbers in this assay, from the lowest: compound 3; then compound 2; then compound 1.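

Taking difluoromethoxy off the six-membered aromatic ring altogether gives a number 0.50 log units lower from compound 2 to compound 3 (beyond the scatter) in this assay and shows that the number at this position still moves once the whole group is gone, not only when the group on the oxygen changes. Hydrogen in place of isopropoxy gives a number 1.00 log units lower from compound 1 to compound 3 (beyond the scatter) and leaves compound 3 lowest of the three. Nothing available explains these steps.

On these data alone, whether an amine or a carboxylic acid at this position would read above or below compound 3 stays open, as does the effect of a longer chain on the oxygen.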